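The compounds below may be only part of what the source reports. "The series", "measured", "known", "first", "only" and "open" are said of these compounds alone.

Compound 1 `COc1cccc(/C=C/C(=O)c2ccc(OCCn3cc(CN4C(=O)/C=C/C(C)(C)C/C=C(\C)CC/C=C/4C)nn3)cc2O)c1` and compound 2 `COc1ccccc1/C=C/C(=O)c1ccc(OCCn2cc(CN3C(=O)/C=C/C(C)(C)C/C=C(\C)CC/C=C/3C)nn2)cc1O` share one core; compound 3 `COc1cccc(/C=C/C(=O)c2ccc(OCCCN3C(=O)/C=C/C(C)(C)C/C=C(\C)CC/C=C/3C)cc2)c1` and compound 4 `COc1ccccc1/C=C/C(=O)c1ccc(OCCCN2C(=O)/C=C/C(C)(C)C/C=C(\C)CC/C=C/2C)cc1` share another. The difference between the two cores is not broken down here. In a functional assay on Lu cells (Homo sapiens) for antiproliferative activity (a higher number here means a weaker inhibitor, a lower number a stronger inhibitor), compound 1 gives 0.61 ug/mL, compound 2 gives 2.4 ug/mL and compound 3 gives 1.06 ug/mL; the values of compound 3 and compound 1 lie within the scatter of each other. Within the first core the change 2-methoxyphenyl in place of 3-methoxyphenyl on a double-bonded chain carbon bound to a double-bonded chain carbon produced a 3.9-fold higher number from compound 1 to compound 2 (0.59 log units; beyond the scatter). The same change 2-methoxyphenyl in place of 3-methoxyphenyl on a double-bonded chain carbon bound to a double-bonded chain carbon is now made in the second core. Going by the values given here, for compound 4 a step of roughly a 3.4-fold higher number from compound 3 to compound 4 (0.53 log units; beyond the scatter) is expected, resting on the single earlier instance a 3.9-fold higher number from compound 1 to compound 2 (0.59 log units; beyond the scatter) and on the value of compound 3 1.06 ug/mL. Compound 4 is therefore estimated at 3.6 ug/mL in this assay, with the likely range running from 1.6 ug/mL to 8 ug/mL.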

Compound 4, half-maximal inhibitory concentration: 2.82 ug/mL
Compound 4: the middle estimate sits 1.3-fold (0.11 log units) above what was measured; the measured number falls inside the stated range.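

Replacing 3-methoxyphenyl with 2-methoxyphenyl also gives a higher number in the second core in this assay, with a 2.7-fold higher number from compound 3 to compound 4 (0.42 log units; beyond the scatter). The two instances run in the same direction and do not differ in size beyond the scatter: the same change on two cores in this assay, a 3.9-fold higher number (0.59 log units; beyond the scatter) from compound 1 to compound 2 and a 2.7-fold higher number (0.42 log units; beyond the scatter) from compound 3 to compound 4, 1.5-fold (0.17 log units) apart, within the scatter of two such steps. Going by these compounds alone, this shows the change carrying across these two cores in this one assay, but with only two pairs it shows nothing about other cores and gives no reason for the step.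

Still open, as far as these compounds go, is how the series responds to a group other than methoxy on this phenyl ring, such as a hydroxyl, an amine or a carboxylic acid. No pair shown differs in one place between the two cores, so the contribution of what separates them remains unread.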